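Trimming the Tail: Cytotoxicity Expected for Compound 4

The compounds below may be only part of what the source reports. "The series", "measured", "known", "first", "only" and "open" are said of these compounds alone.

Compound 1, `Fc1cccc(F)c1Cc1cnc(Nc2ccc(Oc3ccncc3)cc2)o1`: 21000 nM
Compound 2, `N#Cc1ccc(Nc2ncc(Cc3c(F)cccc3F)o2)cc1`: 7400 nM
Compound 3, `O=c1ncccn1SCCc1ccc(Nc2ncc(Cc3c(F)cccc3F)o2)cc1`: > 100000 nM

Three compounds sharing one core have been examined in an ADME assay on MT2 cells (Homo sapiens) for cytotoxicity, read by MTT assay; a lower number here means that less compound is tolerated, a higher number that more compound is tolerated. Compound 3 gives only a limit of the assay rather than a number (the limit of > 100000 nM in this assay, at which 1 of the 3 values shown sits), and it stands highest of the three, with its steps to compound 1 and compound 2 both beyond the scatter. Compound 4, `COCc1ccc(Nc2ncc(Cc3c(F)cccc3F)o2)cc1`, differs from compound 3 by a group of 2 heavy atoms (1 carbon, 1 oxygen; no ring) in place of a group of 9 heavy atoms (5 carbon, 2 nitrogen, 1 oxygen, 1 sulfur; one six-membered aromatic ring with 2 hetero atoms), on a saturated chain carbon bound to an aromatic carbon. The measured steps that bear on this change run in the opposite direction: an at least 4.7-fold higher number from compound 1 to compound 3 (0.67 log units; beyond the scatter) and an at least 13-fold higher number from compound 2 to compound 3 (1.13 log units; beyond the scatter). Each time the large group entered, the number rose. Cutting most of it away, leaving methoxy, is therefore expected to bring the number back down, by a step of an at least 6.6-fold lower number from compound 3 to compound 4 (0.82 log units; beyond the scatter), and compound 4 is estimated at 15000 nM, within a range from 4000 nM to 60000 nM. Among the compounds with values here, since only three compounds lie behind this and compound 3 itself sits at a limit, the size of the expected step remains uncertain, though its direction seems clear.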

Compound 4, half-maximal cytotoxic concentration: 32000 nM
Beside the measured number, compound 4's estimate is 2.1-fold (0.33 log units) below it, and the stated range covers the measured number.
By their numbers in this assay, from the lowest: compound 2; then compounds 1 and 4 (each within the scatter of the next). At a limit, above all of these: compound 3.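

With methoxy on the saturated chain carbon bound to an aromatic carbon, the number falls (an at least 3.1-fold lower number from compound 3 to compound 4 (0.49 log units; beyond the scatter)), which shows that the shared core with this short tail does not keep the tolerance of compound 3. The size of that step remains a bound, since compound 3 holds a limit and not a number: the limit of > 100000 nM in this assay, at which 1 of the 4 values shown sits. Methoxymethyl on the aromatic carbon stands clearly apart from cyano (a 4.3-fold higher number from compound 2 to compound 4 (0.64 log units; beyond the scatter)) but not from (pyridin-4-yl)oxy (a 1.5-fold higher number from compound 1 to compound 4 (0.18 log units; within the scatter)), so these two different groups give numbers that cannot be told apart.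

On these data alone, it remains open whether the high number of compound 3 needs the whole group that left or only a part of it. As far as these compounds go, it is also open how an amine, a carboxylic acid or a longer chain on the same carbon would move the number.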